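Swapping the aryl group on the triazole series

The compounds below may be only part of what the source reports. "The series", "measured", "known", "first", "only" and "open" are said of these compounds alone.

Measured in a functional assay on SGC-7901 cells (Homo sapiens) for inhibition, read by MTT assay, with a stated time of 24 h; on this read-out higher numbers stand for weaker inhibition and lower numbers for stronger inhibition:
- compound 1 `CC1(C)[C@H]2CC[C@]1(C)N(Cc1cn(-c3cccc(F)c3)nn1)C(=O)C2`: 530 nM
- compound 2 `CC1(C)[C@H]2CC[C@]1(C)N(Cc1cn(-c3ccccc3Br)nn1)C(=O)C2`: 500 nM

Within the data shown here, only two numbers exist so far, and they lie within the scatter of each other, so compound 2 at 500 nM cannot be ranked against compound 1 at 530 nM. The next compound, compound 3 `CC1(C)[C@H]2CC[C@]1(C)N(Cc1cn(-c3ccc(C#N)cc3)nn1)C(=O)C2`, keeps the shared core and changes only the aryl group: 4-cyanophenyl in place of 2-bromophenyl on an aromatic nitrogen.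

Among the measured compounds shown here, one measured step bears on this change, since it also exchanges one substituted phenyl group for another at the same place: a 1.1-fold lower number from compound 1 to compound 2 (0.03 log units; within the scatter). For the measured compounds named here, that step is small, but it is a single example, and no measured compound carries the 4-cyanophenyl group. No step beyond the scatter is therefore expected in this assay, though the uncertainty is wide and either direction remains possible. The expected change is a 1.1-fold higher number from compound 2 to compound 3 (0.04 log units; within the scatter). For compound 3 the estimated value is 550 nM, with an expected range of 200 nM to 1500 nM.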

Compound 3, half-maximal inhibitory concentration: 500 nM
The estimate for compound 3 lay 1.1-fold (0.04 log units) above the measured number; low and high end bracket the measured number.
By their numbers in this assay, from the lowest: compounds 2, 3 and 1 (each within the scatter of the next).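

In this assay, putting 4-cyanophenyl in place of 2-bromophenyl gives no change at the digits printed from compound 2 to compound 3 (within the scatter), and putting it in place of 3-fluorophenyl gives a 1.1-fold lower number from compound 1 to compound 3 (0.03 log units; within the scatter). The aromatic nitrogen now carries three different substituted phenyl groups, with bromine, fluorine or a nitrile on the ring, and all three compounds lie within the scatter of one another, even though the 4-cyanophenyl group brings a hydrogen-bond acceptor that 2-bromophenyl lacks. Nothing available explains why these three compounds read alike.

On these data alone, all three compounds keep a six-membered aromatic carbon ring on that nitrogen, so it remains open what a phenyl ring bearing an amine or a carboxylic acid would do, or what a plain alkyl chain in place of the ring would do. The similar numbers hold only for these three compounds in this one assay, and they leave open whether a larger change at this place, or any change elsewhere on the shared core, would move the number beyond the scatter.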